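Trimethoxyphenyl pyrazole chalcones: aryl change at the carbonyl

The compounds below may be only part of what the source reports. "The series", "measured", "known", "first", "only" and "open" are said of these compounds alone.

The series is built around a pyrazole-linked enone. Compound 1 `COc1cc(-c2cc(/C=C/C(=O)c3ccc(N)cc3)[nH]n2)cc(OC)c1OC` carries a 4-aminophenyl on the carbonyl carbon; in a functional assay on SK-OV-3 cells (Homo sapiens) for cytotoxicity, read by sulforhodamine B assay, with a stated time of 48 h, tested at 0.01 uM (a higher number here means a weaker effect of the compound at the concentration tested, a lower number a stronger effect), compound 1 gives 82%. Compound 2 `COc1ccc(-c2cc(/C=C/C(=O)c3ccc(OC)c(OC)c3)[nH]n2)cc1` differs in several places at once and in this assay compound 2 gives 109%. Of the two numbers compound 1 stands lowest, and the gap to compound 2 lies beyond the scatter; since the two structures differ in more than one place, nothing beyond the two values themselves can be said of that pair.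

Compound 3 `COc1cc(-c2cc(/C=C/C(=O)c3ccc(Cl)c(Cl)c3)[nH]n2)cc(OC)c1OC` differs from compound 1 in one place (3,4-dichlorophenyl in place of 4-aminophenyl on a carbonyl carbon). Going by the values given here, no single-change step between measured compounds is available, so the expectation rests on the two values alone. Compound 3 is expected to show a slight weakening, an estimated step of a number 12 percentage points higher from compound 1 to compound 3 (beyond the scatter) close to the scatter. For compound 3 in this assay the estimate is 94%, within 74% to 114%.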

Compound 3, a percentage reported as activity, at one concentration (the size of the read-out at that concentration, not a potency): 99%
Compound 3: middle estimate off by 5 percentage points, on the low side, and the stated range covers the measured number.
By their numbers in this assay, from the lowest: compound 1; then compounds 3 and 2 (each within the scatter of the next).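

Going by these compounds alone, with compound 3, the group on the carbonyl carbon is changed on its own for the first time against the shared core, and in this assay the result is a number 17 percentage points higher from compound 1 to compound 3 (beyond the scatter). This shows that the position is sensitive to the exchange: 3,4-dichlorophenyl in place of 4-aminophenyl gives a weaker effect at the concentration tested, so the lower number of compound 1 now has a single-change comparison behind it. The data offer no measurement that explains why the step runs this way.

Within the data shown here, whether the difference follows the loss of the amine or the arrival of the two chlorines remains open with only this one exchange in hand. As far as these compounds go, a 4-hydroxyphenyl or a 4-dimethylaminophenyl at this position would help to separate the two, and how either would compare with compound 1 is unknown.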